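Replacing an ester-bearing phenyl with a styryl group

The compounds below may be only part of what the source reports. "The series", "measured", "known", "first", "only" and "open" are said of these compounds alone.

Compound 1 `COc1ccccc1-n1nc(C)c2c1NC(=O)[C@H](C)S[C@@H]2c1ccc(Oc2ccccc2)cc1`: 3300 nM
Compound 2 `Cc1nn(-c2ccccc2I)c2c1C(c1ccc(Oc3ccccc3)cc1)SC(C)C(=O)N2`: 1300 nM
Compound 3 `COC(=O)c1cccc(-c2ccc([C@H]3S[C@@H](C)C(=O)Nc4c3c(C)nn4-c3ccccc3C)cc2)c1`: "not active" (no number reported)

In an assay on isolated protein for agonist activity at Bile acid receptor (Homo sapiens), read by AlphaScreen, with a stated time of 30 min (on this read-out higher numbers stand for an effect only at larger amounts of compound and lower numbers for an effect already at smaller amounts), compound 1 gives 3300 nM and compound 2 gives 1300 nM, so the shared core can reach measurable values. Compound 3 stands apart: in this assay compound 3 is reported as "not active" (no number reported), with no single number, so nothing can be said about its distance to compounds 1 and 2. Compound 4 `Cc1ccccc1-n1nc(C)c2c1NC(=O)[C@H](C)S[C@@H]2c1ccc(/C=C/c2ccccc2)cc1` differs from compound 3 in one place: 2-phenylethenyl in place of 3-(methoxycarbonyl)phenyl on an aromatic carbon. Among the measured compounds shown here, no step between measured compounds exists for this change, so the expected direction rests only on compound 3 lacking any activity; a return toward the range of compounds 1 and 2 is plausible but uncertain. Compound 4 is estimated at 4000 nM in this assay, expected within 800 nM to 20000 nM.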

Compound 4, half-maximal effective concentration: "not active" (no number reported)
Compound 4 has no reported number here; the estimate stays without a comparison.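

Compound 3 and compound 4 are both reported as not active, without a number, so no step can be read between them, and nothing available explains this result. From the compounds shown here alone, how 3-(methoxycarbonyl)phenyl and 2-phenylethenyl compare remains open.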